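This account rests on a few compounds, and the source may have more. Where it says the series, first, only, none or still open, it means among the compounds named here.

Measured compounds:
compound 1 `Cc1cc(-c2ccc(O)cc2)c2ncc(CSCCc3ccccc3)n2c1`, 20 ug/mL
compound 2 `Cc1cc(-c2ccsc2)c2ncc(CSCCc3ccccc3)n2c1`, 100 ug/mL
compound 3 `COc1ccc(-c2cc(C)c3ncc(CSCCc4ccccc4)n3c2)cc1`, 20 ug/mL

All three were run in an ADME assay on HEL cells (Homo sapiens) for cytotoxicity, with a stated time of 3 days; a lower number here means that less compound is tolerated, a higher number that more compound is tolerated. Compound 2 stands highest of the three numbers; its nearest neighbour is compound 1, a 5.0-fold higher number from compound 1 to compound 2 (0.70 log units; beyond the scatter), and compound 3 lies equally far from it, with the values of compound 2 and compound 3 showing a gap of the same size, beyond the scatter. Compound 1 and compound 3 sit together within the scatter.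

Compound 4 `COc1ccc(-c2cc(C)cn3c(CSCCc4ccccc4)cnc23)cc1` has not yet been measured in this assay. It differs from compound 2 in one place: 4-methoxyphenyl in place of thiophen-3-yl on an aromatic carbon.

For the measured compounds named here, the only measured step that bears on this change is the one between compound 1 and compound 2, which swapped an aryl group for thiophen-3-yl and moved the number up. Here the direction is reversed: thiophen-3-yl leaves and an aryl group enters. Compound 3, carrying the same 4-methoxyphenyl group, sits at the same value as compound 1, so the entering group has so far been associated with the lower tier of numbers. The expectation is therefore a modest step downward in this assay, a 5.0-fold lower number from compound 2 to compound 4 (0.70 log units; beyond the scatter), back toward the level of compound 1 and compound 3.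

Compound 4 is expected to give about 20 ug/mL, with a range from 10 ug/mL to 50 ug/mL.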

Compound 4, minimum cytotoxic concentration: 20 ug/mL
For compound 4 middle estimate and measured number coincide at the digits printed, and the stated range covers the measured number.
By their numbers in this assay, from the lowest: compounds 1, 3 and 4 (each within the scatter of the next); then compound 2.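

In this assay the exchange at this carbon gives a 5.0-fold lower number from compound 2 to compound 4 (0.70 log units; beyond the scatter) and so repeats, with a second substituted phenyl group on the same carbon, the gap first seen with 4-hydroxyphenyl. Methyl on the oxygen leaves the number in place, with no change at the digits printed from compound 1 to compound 4 (within the scatter), so at this position 4-hydroxyphenyl and 4-methoxyphenyl read as one level and, of the three groups carried here, thiophen-3-yl alone stands apart from them. Nothing at hand gives a reason for that gap between thiophen-3-yl and the two substituted phenyl groups.

The compounds shown leave open whether the higher number goes with the five-membered aromatic ring with its sulfur or simply with the smaller group, since thiophen-3-yl differs from 4-methoxyphenyl in ring size, hetero atom and heavy-atom count at once; plain phenyl and furan-3-yl on this carbon would pull these apart. Also open, going by these compounds, is whether the flat reading across hydroxyl and methoxy extends to an amine or a carboxylic acid on the phenyl ring, and whether the gap survives a change in the phenethyl thioether chain.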